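Compound 4 and the step from compound 2

The source may hold more compounds than are shown below. What is called first, only, known or untested is meant among the compounds shown, and "the series" means these compounds.

Measured so far in a functional assay on HepG2 cells (Homo sapiens) for inhibition, read by MTT assay, with a stated time of 24 h (on this read-out lower numbers stand for stronger inhibition and higher numbers for weaker inhibition), are three compounds.
- compound 1 `Cc1ccc(C(=O)NCC(=O)N/N=C/c2ccccc2OCc2ccccc2Cl)cc1` gives 13400 nM
- compound 2 `O=C(CNC(=O)c1cccnc1Cl)N/N=C/c1ccc(OCc2ccccc2Cl)cc1` gives 4700 nM
- compound 3 `Cc1ccc(C(=O)NCC(=O)N/N=C/c2ccccc2OCc2ccc(C#N)cc2)cc1` gives > 50000 nM (a limit, not a number)

Of the two exact numbers, compound 2 has the lower (4700 nM), and the higher number of compound 1 (13400 nM) lies beyond the scatter. Compound 4 `Cc1ccc(C(=O)NCC(=O)N/N=C/c2ccc(OCc3ccccc3Cl)cc2)cc1` is not yet measured. It carries 4-methylphenyl in place of 2-chloropyridin-3-yl on a carbonyl carbon. Within the data shown here, no measured step tests this change. The only one (an at least 3.7-fold higher number from compound 1 to compound 3 (0.57 log units; beyond the scatter)) concerns a different group and gives no direct guide. Compound 1, which also has 4-methylphenyl on a carbonyl carbon, gives a higher number (13400 nM), and this is the only hint of direction. In this assay the expected step is therefore the small estimated step of a 1.7-fold higher number from compound 2 to compound 4 (0.23 log units; within the scatter). Compound 4 is estimated at 8000 nM (2500 nM to 25000 nM).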

Compound 4, half-maximal inhibitory concentration: 28100 nM
Beside the measured number, compound 4's estimate is 3.5-fold (0.55 log units) below it; measured number outside the range, above it.
By their numbers in this assay, from the lowest: compound 2; then compound 1; then compound 4. At a limit, above all of these: compound 3.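

Among these compounds, the step of a 6.0-fold higher number from compound 2 to compound 4 (0.78 log units; beyond the scatter) in this assay is the first reading at this position, since the only earlier step concerned the group on a saturated chain carbon bound to an oxygen on an aromatic ring. It shows that the group on the carbonyl carbon alone can move the number beyond the scatter, with the higher number going to 4-methylphenyl. The two groups have the same count of heavy atoms, but the change removes a ring nitrogen and a chlorine and adds a methyl together, so this single step cannot separate their shares.

From the compounds shown here alone, whether 2-chlorophenyl or pyridin-3-yl on this carbonyl carbon would stay closer to compound 2 or to compound 4 remains open. Compound 3 remains a limit, not a number: the limit of > 50000 nM in this assay, at which 1 of the 4 values shown sits.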